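The source may hold more compounds than are shown below. What is called first, only, known or untested is meant among the compounds shown, and "the series" means these compounds.

Of the compounds shown here, three have been measured in an assay on isolated protein for binding affinity to adenosine receptor A1 (Bos taurus); a higher number here means a weaker inhibitor, a lower number a stronger inhibitor: compound 1 `CCCNc1nc(-c2ccccc2)nc2c1nnn2Cc1ccccc1F` gives 3200000 nM; compound 2 `CNc1nc(-c2ccccc2)nc2c1nnn2Cc1ccccc1F` gives 25000000 nM; compound 3 `CC(O)CNc1nc(-c2ccccc2)nc2c1nnn2Cc1ccccc1F` gives 4800000 nM.

Compound 1 sits at the low end of these numbers together with compound 3, the step of a 1.5-fold higher number from compound 1 to compound 3 (0.18 log units; within the scatter) being within the scatter, while the step of a 7.8-fold higher number from compound 1 to compound 2 (0.89 log units; beyond the scatter) is beyond it. Compound 4 `CCCNc1nc(-c2ccccc2)nc2c1nnn2Cc1ccccc1` differs from compound 1 by hydrogen in place of fluoro on an aromatic carbon. Every measured step concerns the chain on the ring nitrogen, so none bears on this change, and no guidance exists for it. A step of no more than the scatter is therefore expected, a 1.3-fold higher number from compound 1 to compound 4 (0.10 log units; within the scatter). Compound 4 is estimated at 4000000 nM in this assay, with a range from 1500000 nM to 12000000 nM.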

Compound 4, inhibition constant: 37000000 nM
Compound 4: middle estimate off by 9.3-fold (0.97 log units), on the low side; the whole stated range lies below it.
By their numbers in this assay, from the lowest: compounds 1 and 3 (each within the scatter of the next); then compounds 2 and 4 (each within the scatter of the next).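

Replacing fluoro with hydrogen on this aromatic carbon gives, in this assay, a 12-fold higher number from compound 1 to compound 4 (1.06 log units; beyond the scatter). Among these compounds, the 2-fluorobenzyl group, constant across the earlier compounds, therefore proves sensitive to a one-atom change, and this step is of similar size to the largest step on the nitrogen chain, a 7.8-fold higher number from compound 1 to compound 2 (0.89 log units; beyond the scatter). Nothing available explains why fluoro and hydrogen differ here.

As far as these compounds go, it remains open whether chloro or methyl on this carbon would match fluoro. It is also unknown whether the same swap would have a similar effect alongside the other chains, such as that of compound 3.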